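The source may hold more compounds than are shown below. What is called first, only, known or untested is meant among the compounds shown, and "the series" means these compounds.

Measured compounds:
- compound 1 `CS(=O)(=O)c1cccc(-c2ccc(-n3cc(-c4ccccc4)nn3)cc2)c1`, in a functional assay on MCF7 cells (Homo sapiens) for inhibition, read by resazurin assay, with a stated time of 72 h (on this read-out higher numbers stand for weaker inhibition and lower numbers for stronger inhibition), compound 1 gives < 50000 nM, a limit of the assay rather than a number.
- compound 2 `N#Cc1cncc(-c2ccc(-n3cc(-c4ccccc4)nn3)cc2)c1`, in this assay compound 2 gives < 50000 nM, again a limit and not a number.

Within the data shown here, compound 2 therefore stands at the edge of what this assay reports, and the same holds for the only other value shown, as the limit of < 50000 nM in this assay, at which 2 of the 2 values shown sit, records. Among the measured compounds shown here, two limits give no measured step and no ordering; they show only that both compounds sit at the limit.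

Compound 3 `Cc1ccccc1-c1ccc(-n2cc(-c3ccccc3)nn2)cc1` has not yet been measured in this assay. It differs from compound 2 in one place: 2-methylphenyl in place of 5-cyanopyridin-3-yl on an aromatic carbon, para to a large group. For the measured compounds named here, no measured pair shows what such a change does here, so no step beyond the scatter can be expected in either direction from the numbers at hand; the expected step from compound 2 to compound 3 is a step that the limit leaves unreadable from compound 2 to compound 3, set merely as a best guess. Compound 3 is expected to give about 15000 nM in this assay, estimated within a range from 3000 nM to 50000 nM.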

Compound 3, half-maximal inhibitory concentration: < 50000 nM
Compound 3: no number, only a limit; the forecaster's own chance of this, stated with the estimate: 50%; the middle value is on the limit's open side.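

Compound 2 and compound 3 each give only a limit of the assay and not a number, so no step can be read between them, and compound 1 stands at the same edge: the limit of < 50000 nM in this assay, at which 3 of the 3 values shown sit.

The compounds shown leave open how strongly each one actually inhibits in this assay and whether 2-methylphenyl or 5-cyanopyridin-3-yl gives stronger inhibition.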